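Trimethoxyphenyl series: dichlorophenyl in place of methoxynaphthyl

The compounds below may be only part of what the source reports. "The series", "measured", "known", "first", "only" and "open" are said of these compounds alone.

Measured compounds:
compound 1, `COc1cc(N2C(N)=C(C#N)C(c3ccc(O)cc3)C3=C2CC(C)(C)CC3=O)cc(OC)c1OC` — 75800 nM
compound 2, `COc1cc(N2C(N)=C(C#N)C(c3c(OC)ccc4ccccc34)C3=C2CC(C)(C)CC3=O)cc(OC)c1OC` — "not active" (no number reported)

The two measured compounds share one core and differ only in the aryl group on the saturated ring carbon. In a functional assay on Ehrlich cells (Mus musculus) for cytotoxicity (a higher number here means a weaker inhibitor, a lower number a stronger inhibitor), compound 1 gives 75800 nM, a weak result. In this assay compound 2 is reported as "not active" (no number reported), so no number stands for it; on the numbers shown, compound 2 is the one without a measurable value, and compound 1 the only one with a figure.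

Compound 3, `COc1cc(N2C(N)=C(C#N)C(c3ccc(Cl)cc3Cl)C3=C2CC(C)(C)CC3=O)cc(OC)c1OC`, is not yet measured. It differs from compound 2 in one place: 2,4-dichlorophenyl in place of 2-methoxynaphthalen-1-yl on a saturated ring carbon. Since compound 2 has no number, the size of the step cannot be set against a value; the expected direction in this assay is toward a measurable but still weak inhibition, of the order seen for compound 1, with a real chance that only a limit is returned again.

Compound 3 is expected to give about 60000 nM in this assay, estimated within 15000 nM to 250000 nM.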

Compound 3, half-maximal inhibitory concentration: 94700 nM
The estimate for compound 3 lay 1.6-fold (0.20 log units) below the measured number, within the range that was stated.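

In this assay, 2,4-dichlorophenyl in place of 4-hydroxyphenyl on the saturated ring carbon gives a 1.2-fold higher number from compound 1 to compound 3 (0.10 log units; within the scatter), so the two aryl groups that carry a figure at this position cannot be told apart. Compound 3 also shows that this position can return a measurable figure with 2,4-dichlorophenyl where 2-methoxynaphthalen-1-yl gave none, although compound 2 has no number and that change therefore cannot be read as a step. No measurement in hand bears on what lies behind these results, either the matching figures of the two aryl groups or the missing figure for compound 2.

As far as these compounds go, it remains open whether anything other than these aryl groups on this carbon, such as a plain methyl, a cyclohexyl ring, or a phenyl ring carrying an amine or a carboxylic acid, would move the number beyond the scatter. From the compounds shown here alone, it is equally open how far the figures depend on the 3,4,5-trimethoxyphenyl group, which all three compounds share, since no replacement for it, such as an unsubstituted phenyl ring, appears here.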